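The source may hold more compounds than are shown below. What is called first, only, known or untested is meant among the compounds shown, and "the series" means these compounds.

Series notes, step from compound 3 to compound 4.

Compound 3 `Nc1nc(NC2CCCCC2)c2ncn(/C=C3/CC3(CO)CO)c2n1` carries a cyclohexylamino group on the shared core. In an ADME assay on CCRF-HSB-2 cells (Homo sapiens) for cytotoxicity, with a stated time of 7 days (on this read-out higher numbers stand for lower toxicity in this test and lower numbers for higher toxicity in this test), compound 3 returns only a limit, > 20000 nM. Compound 2 `Nc1nc(NC2CCCC2)c2ncn(/C=C3/CC3(CO)CO)c2n1`, the cyclopentylamino analogue, likewise returns only a limit in this assay, > 20000 nM. Going by the values given here, compound 1 `CCCSc1nc(N)nc2c1ncn2/C=C1/CC1(CO)CO`, with propylsulfanyl at the same carbon, is the one member with a number: in this assay compound 1 gives 98000 nM. The measured steps stay unreadable: a step that the limit leaves unreadable from compound 1 to compound 2, a step that the limit leaves unreadable from compound 1 to compound 3 and a step that the two limits leave unreadable from compound 2 to compound 3, which follows from the limit of > 20000 nM in this assay, at which 2 of the 3 values shown sit. On the numbers shown, compound 3 therefore stands at the low-toxicity end of what the assay reports, with no value that would rank it against compound 2 or compound 1.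

Compound 4 `Nc1nc(SCc2ccccc2)c2ncn(/C=C3/CC3(CO)CO)c2n1` differs from compound 3 in one place: benzylsulfanyl in place of cyclohexylamino on an aromatic carbon. Among the compounds with values here, no measured step bears on a benzylsulfanyl group; the nearest point of reference is compound 1, the only sulfanyl analogue, which sits at a number rather than a limit. A readable step is not expected, and the expected step for compound 4 is a step that the limit leaves unreadable from compound 3 to compound 4 in this assay. The estimate for compound 4 in this assay is 50000 nM, expected between 10000 nM and 200000 nM.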

Compound 4, half-maximal cytotoxic concentration: > 100000 nM
Compound 4: a limit, no number (the forecaster's own chance of this, stated with the estimate: 40%); at least 2.0-fold (0.30 log units) between middle value and limit.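

Compound 4 returns only a limit in this assay, > 100000 nM. Against compound 1, the other sulfanyl analogue, the change of ethyl to phenyl on the chain bound to sulfur gives an at least 1.0-fold higher number from compound 1 to compound 4 (0.00 log units; that floor lies within the scatter), so this pair cannot be ordered, and the larger benzylsulfanyl group at this carbon brings no readable rise in toxicity over propylsulfanyl. The steps to compound 4 from compound 2 and from compound 3 cannot be read, because each pair has a limit at both ends, and the lower limit shared by the two amino analogues leaves them open to lying anywhere in the range of the two sulfanyl members: the limit of > 20000 nM in this assay, at which 2 of the 4 values shown sit.

The compounds shown give no measured number for any amino member at this carbon, so whether sulfanyl and amino groups differ here in this assay stays open, as does any effect of ring size between cyclopentylamino and cyclohexylamino. Also open, as far as these compounds go, is whether a group of another kind on this aromatic carbon, such as a morpholine or a methoxy group, would give a number in the range where the series could be ranked.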